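This account rests on a few compounds, and the source may have more. Where it says the series, first, only, none or still open, it means among the compounds named here.

Series notes, cysteinyl leukotriene antagonism on trachea.

Compound 1 `O=C(O)c1ccc(SC(/C=C\Cc2ccc(OCCCCOc3ccccc3)cc2)C(=O)O)cc1` gives 6.4 in a functional assay on trachea for antagonist activity at cysteinyl leukotriene receptor 1 (Cavia porcellus), tested at 1 uM; on this read-out higher numbers stand for higher potency (the scale is a negative logarithm) and lower numbers for lower potency. Among the compounds with values here, compound 2 `O=C(O)CC(/C=C\Cc1ccc(OCCCCOc2ccccc2)cc1)Sc1ccc(C(=O)O)cc1` gives 6.9 in this assay, the higher of the two numbers measured so far; the only measured step, a number 0.50 log units higher from compound 1 to compound 2 (beyond the scatter), moves the acid one carbon out from the chain carbon that carries the sulfur and the double-bonded carbon.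

Compound 3 `O=C(O)CCCC(/C=C\Cc1ccc(OCCCCOc2ccccc2)cc1)Sc1ccc(C(=O)O)cc1` is not yet measured. It carries the change (2-carboxyethyl in place of carboxy on a saturated chain carbon, two bonds along the chain from a double-bonded chain carbon and a sulfur), so the acid sits two carbons further from the chain than in compound 2 and three further than in compound 1.

The step from compound 1 to compound 2 is the only one that bears on this, and it was modest but beyond the scatter in the upward direction. Whether a further homologation continues that trend, levels off, or reverses cannot be read from two points. Within the data shown here, the expected step of a number 0.10 log units higher from compound 2 to compound 3 (within the scatter) is therefore small, with an upward lean drawn from the single step seen, and a wide spread. Compound 3 is estimated at 7 in this assay, with a range from 6.3 to 7.6.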

Compound 3, negative logarithm of the antagonist equilibrium constant: 7
Compound 3: middle estimate and measured number agree at the digits printed, within the range that was stated.
By their numbers in this assay, from the lowest: compound 1; then compounds 2 and 3 (each within the scatter of the next).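

With a number 0.10 log units higher from compound 2 to compound 3 (within the scatter) in this assay as the read-out, the change from carboxymethyl to 3-carboxypropyl on this saturated chain carbon does not separate the two compounds, so a single upward step no longer describes this position. The longer acid chain still keeps its distance from the shortest one, with a number 0.60 log units higher from compound 1 to compound 3 (beyond the scatter) as the step, which shows that the result seen with carboxymethyl is not confined to that one chain length and that, among these three compounds, only compound 1 stands apart. No measurement is available that explains this flat stretch or the difference from compound 1.

Three compounds do not show whether a longer chain, such as 4-carboxybutyl, would hold this level or fall away from it, so no optimum chain length can be placed at this position. On these data alone, it also remains open whether the terminal carboxylic acid of this chain is needed at all, which a primary amide or a tetrazole at the same chain end would test, and whether the ring-bound carboxy group responds in the same way.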